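Chloropyrazole for isoxazole on the furan-carboxamide series

A few compounds are considered here, and "the series" means these few. Any claim that something is new, unique, unknown or untested is made for them only; others in the source may bear on it.

Measured compounds:
compound 1 `Cc1cc(C)n(Cc2ccc(C(=O)Nc3c[nH]nc3C(N)=O)o2)n1`, a functional assay on HT-1080 cells (Homo sapiens) for inhibition, read by WST assay and cell counting, with a stated time of 72 h (on this read-out higher numbers stand for weaker inhibition and lower numbers for stronger inhibition), 66600 nM
compound 2 `CCn1cc(NC(=O)c2ccc(Cc3c(C)noc3C)o2)c(C(N)=O)n1`, this assay > 100000 nM
compound 3 `CCn1cc(NC(=O)c2cccc(Cn3nc(C)cc3C)c2)c(C(N)=O)n1`, this assay 50200 nM

Compound 2 stands at the edge of the numbers shown: its result is only a limit of this assay, (the limit of > 100000 nM in this assay, at which 1 of the 3 values shown sits), so no number is known for it. Compound 4 `CCn1cc(NC(=O)c2ccc(Cn3nc(C)c(Cl)c3C)o2)c(C(N)=O)n1` differs from it in one place, (4-chloro-3,5-dimethyl-1H-pyrazol-1-yl in place of 3,5-dimethyl-1,2-oxazol-4-yl on a saturated chain carbon bound to an aromatic carbon). Compound 1 and compound 3, which carry a dimethylpyrazol-1-yl methyl group, both return measured numbers in this assay, with compound 1 at 66600 nM and compound 3 at 50200 nM. Compound 4 is therefore expected to come back into the measurable range, a step of an at least 1.6-fold lower number from compound 2 to compound 4 (0.22 log units; that floor lies within the scatter) being the estimate. The estimate for compound 4 is 60000 nM, with a range from 20000 nM to 150000 nM.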

Compound 4, half-maximal inhibitory concentration: 7400 nM
Compound 4: middle estimate off by 8.1-fold (0.91 log units), on the high side; measured number below the stated range.
By their numbers in this assay, from the lowest: compound 4; then compounds 3 and 1 (each within the scatter of the next). At a limit, above all of these: compound 2.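

In this assay, the place on a saturated chain carbon bound to an aromatic carbon proves responsive: 4-chloro-3,5-dimethyl-1H-pyrazol-1-yl in place of 3,5-dimethyl-1,2-oxazol-4-yl gives an at least 13-fold lower number from compound 2 to compound 4 (1.13 log units; beyond the scatter). Among the compounds shown here, the earlier compounds offered no such pair, so this is the first step that can be read at this position. Its size is only a floor, as compound 2 has no number, only a limit: the limit of > 100000 nM in this assay, at which 1 of the 4 values shown sits.

The compounds shown leave open whether the chlorine or the change of ring carries the step, as the swap alters both at once. As far as these compounds go, whether bromine or a methyl group could stand in for the chlorine also remains open.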